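Swapping the Halogenated Phenyl on a Weak Antiproliferative

The source may report more compounds than this note shows. Statements on the series, on what has been measured and on what is new or still open speak of the compounds shown alone.

Of the compounds shown here, two sharing one core have been tested in a functional assay on A549 cells (Homo sapiens) for antiproliferative activity, read by MTT assay, with a stated time of 72 h; on this read-out lower numbers stand for stronger inhibition and higher numbers for weaker inhibition. Compound 1 `CCCNC(=O)c1cc(Oc2ccc(NC(=O)c3nn(-c4ccc(Br)cc4F)c(=O)cc3C)cc2F)ccn1` gives 235000 nM in this assay, the higher of the two numbers recorded, so it is the weaker of the pair. Compound 2 `CCNC(=O)c1cc(Oc2ccc(NC(=O)c3nn(-c4ccc(Br)cc4F)c(=O)cc3C)cc2)ccn1` differs from compound 1 in several places. In this assay compound 2 gives 34500 nM, a lower number that lies beyond the usual scatter. Within the data shown here, no pair of measured compounds differs in only one place, so no single change can yet be linked to a shift in the read-out.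

Compound 3 `CCCNC(=O)c1cc(Oc2ccc(NC(=O)c3nn(-c4cccc(F)c4)c(=O)cc3C)cc2F)ccn1` has not been measured. It differs from compound 1 in one place: 3-fluorophenyl in place of 4-bromo-2-fluorophenyl on an aromatic nitrogen. Nothing measured here shows how this particular change affects growth inhibition, so the expectation rests on compound 1 alone. A step of little or no size beyond the scatter is expected, a 1.2-fold higher number from compound 1 to compound 3 (0.08 log units; within the scatter), with a modest weakening judged slightly more likely than a gain. Compound 3 is therefore estimated at 280000 nM in this assay, within a range from 70000 nM to 1000000 nM.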

Compound 3, half-maximal inhibitory concentration: 7020 nM
Beside the measured number, compound 3's estimate is 40-fold (1.60 log units) above it; the measured number lies below the stated range.
By their numbers in this assay, from the lowest: compound 3; then compound 2; then compound 1.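

In this assay the group on the aromatic nitrogen of the shared core proves far from a passive part of the structure: putting 3-fluorophenyl in place of 4-bromo-2-fluorophenyl gives a 33-fold lower number from compound 1 to compound 3 (1.52 log units; beyond the scatter) with nothing else in the molecule altered. Among these compounds, this is the first single change that can be read, and it shows that a swap of one phenyl group for another, which loses only the bromine and moves the fluorine, is enough to shift growth inhibition strongly. Nothing measured here explains why so small an edit has so large an effect.

On these data alone, the swap bundles two edits, so it remains open whether the gain comes from losing the bromine or from the new placing of the fluorine, a question that an unsubstituted phenyl, a 4-bromophenyl or a 2-fluorophenyl on the same nitrogen could help to settle. As far as these compounds go, it is equally open whether 3-fluorophenyl would act in the same way on the core of compound 2, and whether a 3-chlorophenyl or a 3-methoxyphenyl would go further still.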